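Pentyl amide compound 4 against the cyclohexyl comparator

The source may report more compounds than this note shows. Statements on the series, on what has been measured and on what is new or still open speak of the compounds shown alone.

Within the data shown here, compound 3 `CO[C@@H]1[C@@H](O)[C@@H](O)[C@H](Oc2ccc3cc(NC(=O)C4CCCCC4)c(=O)oc3c2C)OC1(C)C` gives 46800 nM in a functional assay on SK-BR-3 cells (Homo sapiens) for antiproliferative activity (on this read-out higher numbers stand for weaker inhibition and lower numbers for stronger inhibition), the lowest of the three numbers measured so far. Compound 2 `CCCCCCC(=O)Nc1cc2ccc(O[C@@H]3OC(C)(C)[C@H](OC)[C@@H](O)[C@H]3O)c(C)c2oc1=O` gives 58300 nM in this assay, and compound 1 `CCC(=O)Nc1cc2ccc(O[C@@H]3OC(C)(C)[C@H](OC)[C@@H](O)[C@H]3O)c(C)c2oc1=O` gives 643000 nM. Two steps are large: an 11-fold lower number from compound 1 to compound 2 (1.04 log units; beyond the scatter) and a 14-fold lower number from compound 1 to compound 3 (1.14 log units; beyond the scatter). The third, a 1.2-fold lower number from compound 2 to compound 3 (0.10 log units; within the scatter), stays within the scatter.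

Compound 4 `CCCCCC(=O)Nc1cc2ccc(O[C@@H]3OC(C)(C)[C@H](OC)[C@@H](O)[C@H]3O)c(C)c2oc1=O` differs from compound 3 by pentyl in place of cyclohexyl on a carbonyl carbon. The step that bears most directly on this change is a 1.2-fold lower number from compound 2 to compound 3 (0.10 log units; within the scatter), which shows hexyl and cyclohexyl on the carbonyl carbon giving indistinguishable numbers. Pentyl is shorter than the hexyl of compound 2 and longer than the ethyl of compound 1, and the large gap an 11-fold lower number from compound 1 to compound 2 (1.04 log units; beyond the scatter) leaves room for pentyl to fall short of hexyl. Compound 4 is therefore expected to give a number near compound 2, the step of a 1.6-fold higher number from compound 3 to compound 4 (0.20 log units; within the scatter) expected to be small and upward if anything. The estimate for compound 4 is 75000 nM, with a range from 30000 nM to 220000 nM.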

Compound 4, half-maximal inhibitory concentration: 84000 nM
Estimate against measurement, compound 4: 1.1-fold (0.05 log units) below; the measured number falls inside the stated range.
By their numbers in this assay, from the lowest: compounds 3, 2 and 4 (each within the scatter of the next); then compound 1.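

Pentyl on the carbonyl carbon sits with both larger groups in this assay: the swap from cyclohexyl gives (a 1.8-fold higher number from compound 3 to compound 4 (0.25 log units; within the scatter)) and the shortening from hexyl gives (a 1.4-fold higher number from compound 2 to compound 4 (0.16 log units; within the scatter)), so neither the loss of the ring nor the shorter open chain separates these compounds at this position. Pentyl still differs clearly from the shorter chain, with (a 7.7-fold lower number from compound 1 to compound 4 (0.88 log units; beyond the scatter)) lying beyond the scatter, which leaves compound 1 alone apart from compounds 2, 3 and 4. Nothing measured on these compounds offers an explanation for this pattern.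

From the compounds shown here alone, whether propyl or butyl on the carbonyl carbon already reaches the level of compounds 2, 3 and 4 remains open. Also open, going by these compounds, is whether a longer chain such as octyl, or a chain carrying an amine or a carboxylic acid, would move the number beyond the scatter of these three compounds.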